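The source may hold more compounds than are shown below. What is called first, only, known or untested is meant among the compounds shown, and "the series" means these compounds.

In an ADME assay on cells (Hepatocyte, Homo sapiens) for metabolic stability, with a stated time of 30 min (a lower number here means that less of the compound is left, a higher number that more of the compound is left), compound 1 (`O=c1cc(N2CCN(CC3CCC(NS(=O)(=O)c4ccccc4)CC3)CC2)sc2c([N+](=O)[O-])cc(C(F)(F)F)cc12`), with (phenylsulfonyl)amino on a saturated ring carbon, gives 90.8%. Compound 2 (`CC(=O)OC1CCC(CN2CCN(c3cc(=O)c4cc(C(F)(F)F)cc([N+](=O)[O-])c4s3)CC2)CC1`), with acetoxy at that carbon, gives 0%, and compound 3 (`O=C(OC1CCC(CN2CCN(c3cc(=O)c4cc(C(F)(F)F)cc([N+](=O)[O-])c4s3)CC2)CC1)c1ccco1`), with ((furan-2-yl)carbonyl)oxy there, gives 1%. Compound 3 therefore stands level with compound 2, within the scatter, and far under compound 1.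

Compound 4 (`O=C(OC1CCC(CN2CCN(c3cc(=O)c4cc(C(F)(F)F)cc([N+](=O)[O-])c4s3)CC2)CC1)c1ccc(F)cc1`) has 4-fluorophenyl in place of furan-2-yl on a carbonyl carbon. The measured step closest to this change, made on the same carbonyl carbon, is small: a number 1 percentage points higher from compound 2 to compound 3 (within the scatter). The two large steps, a number 90.8 percentage points lower from compound 1 to compound 2 (beyond the scatter) and a number 89.8 percentage points lower from compound 1 to compound 3 (beyond the scatter), both remove (phenylsulfonyl)amino. Compound 4 does not restore that group, as it carries ((4-fluorophenyl)carbonyl)oxy at the saturated ring carbon. These two steps therefore give no reason to expect a recovery. For the measured compounds named here, no measured compound has a six-membered aromatic ring on this carbonyl carbon, so the expectation rests on a single small step. No change beyond the scatter is expected in this assay, and the expected step is a number 1 percentage points higher from compound 3 to compound 4 (within the scatter). For compound 4 the estimated value is 2%, with an expected range from 0% to 10%.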

Compound 4, percent of the compound remaining: 3%
Beside the measured number, compound 4's estimate is 1 percentage points below it; low and high end bracket the measured number.
By their numbers in this assay, from the lowest: compounds 2, 3 and 4 (each within the scatter of the next); then compound 1.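

In this assay the carbonyl carbon now carries a third kind of group, and the six-membered aromatic ring of 4-fluorophenyl leaves the read-out where methyl and furan-2-yl left it, with a number 2 percentage points higher from compound 3 to compound 4 (within the scatter) and a number 3 percentage points higher from compound 2 to compound 4 (within the scatter) as the two small steps on this carbon. None of the three groups shown here moves the percentage remaining out of the scatter, and the distance to the sulfonamide stays large, at a number 87.8 percentage points lower from compound 1 to compound 4 (beyond the scatter) when ((4-fluorophenyl)carbonyl)oxy stands in place of (phenylsulfonyl)amino on the saturated ring carbon. Nothing in the data shown accounts for this flat pattern or for the large gap to compound 1.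

Still open, going by these compounds, is whether the low values go with the oxygen next to the carbonyl group or with the acyl part, which a benzamide on the saturated ring carbon, with nitrogen in that oxygen's place, would separate. Also open, on these data alone, is whether any group on the carbonyl carbon can shift the read-out in the ester series, and a carbamate, with an amine on that carbon, would be a direct test.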